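The compounds below may be only part of what the source reports. "The series", "measured", "known", "first", "only" and "open" are said of these compounds alone.

Of the compounds shown here, three of one shared core have been measured. Compound 1 `CNC(=O)c1cc(C(=O)NCCCC2CNCCO2)cn(Cc2ccccc2)c1=O`, compound 2 `CNC(=O)c1cc(C(=O)NC2CC2)cn(Cc2ccc3nc[nH]c3c2)c1=O` and compound 3 `CNC(=O)c1cc(C(=O)NCCO)cn(Cc2ccccc2)c1=O` differ only in the groups hung on that core.

In a physicochemical assay for solubility (a higher number here means a more soluble compound, a lower number a less soluble compound), compound 1 gives >= 194 ug/mL, which is a limit of the assay and not a number. In this assay compound 3 gives >= 140 ug/mL, again a limit rather than a number. The step that the two limits leave unreadable from compound 1 to compound 3 cannot be read because the limit of >= 140 ug/mL in this assay, at which 1 of the 3 values shown sits, and the limit of >= 194 ug/mL in this assay, at which 1 of the 3 values shown sits, are both limits. In this assay compound 2 gives >= 163 ug/mL, also a limit and not a number, so compound 2 stands at the limit of >= 163 ug/mL in this assay, at which 1 of the 3 values shown sits, and no ordering among the three compounds can be drawn.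

Compound 4 `CNC(=O)c1cc(C(=O)NC2CC2)cn(Cc2cccc3cn[nH]c23)c1=O` is not yet measured. It differs from compound 2 by 1H-indazol-7-yl in place of 1H-benzimidazol-6-yl on a saturated chain carbon bound to an aromatic nitrogen; the two compounds hold the same atoms, joined differently. Among the compounds with values here, no measured step in this assay touches a change of this kind, and the one measured step is unreadable. With no evidence pointing up or down, the step that the limit leaves unreadable from compound 2 to compound 4 is expected to stay within the scatter. Compound 4 is therefore estimated at 170 ug/mL, with a range from 70 ug/mL to 300 ug/mL, and a limit rather than a number is likely again.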

Compound 4, solubility: >= 181 ug/mL
Compound 4 ended at the assay's limit; the forecaster's own chance of this, stated with the estimate: 65%; middle value at least 1.0-fold (0.02 log units) from the limit.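

In this assay compound 4 gives >= 181 ug/mL, a limit of the assay and not a number. Compound 2 also stands at a limit, and the step between compound 2 and compound 4 cannot be read. The compounds shown leave open whether 1H-indazol-7-yl in place of 1H-benzimidazol-6-yl changes the read-out in this assay at all.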